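Compound 4: An Amino Group Enters the Core of Compound 3

A few compounds are considered here, and "the series" means these few. Any claim that something is new, unique, unknown or untested is made for them only; others in the source may bear on it.

The measured compounds and their numbers in a functional assay on NCI-H2228 cells (Homo sapiens) for inhibition, read by CCK-8 assay (a higher number here means a weaker inhibitor, a lower number a stronger inhibitor), are:

compound 1, `CC[S+]([O-])c1ccccc1Nc1nc(Nc2ccc(N3CCN(C)CC3)cc2OC)ncc1Cl`: 35.2 nM
compound 2, `CC[S+]([O-])c1cc(F)ccc1Nc1nc(Nc2ccc(N(C)CCN(C)C)cc2OC)ncc1Cl`: 84.3 nM
compound 3, `CC[S+]([O-])c1ccccc1Nc1nc(Nc2ccc(N(C)CCN(C)C)cc2OC)ncc1Cl`: 69.3 nM

Compound 3 gives the second highest of the three numbers. Its nearest neighbour is compound 2, and the step of a 1.2-fold lower number from compound 2 to compound 3 (0.09 log units; within the scatter) lies within the scatter. The furthest is compound 1, and the step of a 2.0-fold higher number from compound 1 to compound 3 (0.29 log units; within the scatter) also lies within the scatter. All three values therefore sit in one narrow band.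

Compound 4, `CC[S+]([O-])c1ccccc1Nc1nc(Nc2cc(N)c(N(C)CCN(C)C)cc2OC)ncc1Cl`, differs from compound 3 as follows: amino in place of hydrogen on an aromatic carbon. Among the compounds with values here, no measured step puts an amino group in place of a hydrogen, so neither a 2.0-fold higher number from compound 1 to compound 3 (0.29 log units; within the scatter) nor a 1.2-fold lower number from compound 2 to compound 3 (0.09 log units; within the scatter) speaks to this change directly; they show only that the other changes around this part of the core moved the number little. With nothing to point either way, no step beyond the scatter is expected.

Compound 4 is therefore estimated at 70 nM, with a range from 30 nM to 170 nM, which means an expected step of a 1.0-fold higher number from compound 3 to compound 4 (0.00 log units; within the scatter).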

Compound 4, half-maximal inhibitory concentration: 2630 nM
Estimate against measurement, compound 4: 38-fold (1.57 log units) below, and the stated range ends below it.
By their numbers in this assay, from the lowest: compounds 1, 3 and 2 (each within the scatter of the next, the first and the last beyond it); then compound 4.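

The step of a 38-fold higher number from compound 3 to compound 4 (1.58 log units; beyond the scatter) in this assay is the only step shown that lies beyond the scatter, so this aromatic carbon, ortho to the (2-(dimethylamino)ethyl)(methyl)amino group and para to the methoxy group, is sensitive in a way the earlier compounds did not reveal. An amino group of one heavy atom in place of hydrogen is enough to produce this large step, whereas the two earlier single changes stayed within the scatter. No measurement given here accounts for the step.

The compounds shown leave open whether the loss is specific to the amino group or extends to other groups on this carbon, such as a methyl, a hydroxyl or an acetamide. They also leave open whether the amino group would produce a similar step alongside the 4-methylpiperazin-1-yl group of compound 1.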